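The compounds below may be only part of what the source reports. "The series", "measured", "known", "first", "only" and "open" are said of these compounds alone.

Of the compounds shown here, two have so far been measured in a functional assay on DU-145 cells (Homo sapiens) for antiproliferative activity, read by MTT assay, with a stated time of 72 h; on this read-out higher numbers stand for weaker inhibition and lower numbers for stronger inhibition. Compound 1 `O=C(COc1ccc(C(=O)/C=C/c2ccc(F)c(F)c2)cc1)N[C@H]1CCOC1=O` gives 19800 nM in this assay. Compound 2 `Cc1cc(Cl)ccc1NCC(=O)N[C@H]1CCOC1=O` returned no number at all: in this assay compound 2 gives > 64000 nM, which is a limit of the assay and not a measured value. Compound 2 therefore stands at the limit of > 64000 nM in this assay, at which 1 of the 2 values shown sits, so its reading cannot be placed against that of compound 1 beyond saying that it was not resolved.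

Compound 3 `O=C(CNc1ccc(Cl)cc1)N[C@H]1CCOC1=O` is the next compound to be tested. It differs from compound 2 in one place: hydrogen in place of methyl on an aromatic carbon. For the measured compounds named here, no step between two measured compounds is available to show how such a change moves the read-out in this assay, so the expectation rests on compound 2 alone. Because compound 2 sits at the limit of > 64000 nM in this assay, at which 1 of the 2 values shown sits, the expected step is a step that the limit leaves unreadable from compound 2 to compound 3, meaning no movement beyond the usual scatter, and compound 3 is more likely to return a limit than a number. Compound 3 is estimated at 80000 nM, within a range from 30000 nM to 200000 nM.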

Compound 3, half-maximal inhibitory concentration: > 64000 nM
Compound 3: no number, only a limit (the forecaster's own chance of this, stated with the estimate: 75%); the middle value is on the limit's open side.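

No step can be read from compound 2 to compound 3 in this assay, because both compounds stop at a limit of the assay and neither gives a number: the limit of > 64000 nM in this assay, at which 2 of the 3 values shown sit. The compounds shown leave open whether hydrogen in place of methyl on an aromatic carbon moves this read-out at all, and in which direction.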